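The source may hold more compounds than are shown below. What is called first, only, known or untested is meant among the compounds shown, and "the series" means these compounds.

In an ADME assay on MDCK cells (Canis lupus familiaris) for cytotoxicity, with a stated time of 48 h (a lower number here means that less compound is tolerated, a higher number that more compound is tolerated), compound 1 (`C=C(C(=O)OC)[C@@H]1CC[C@H](C)[C@H]2C(=C(C)C(=O)[C@H]2NC(=O)CC#N)C1`) gives 1450 uM, compound 2 (`C=C(C(=O)Nc1ccc(B(O)O)cc1)[C@@H]1CC[C@H](C)[C@@H]2CC(=O)C(C)=C2C1`) gives 939 uM and compound 3 (`C=C(C(=O)Nc1cccc(B(O)O)c1)[C@@H]1CC[C@H](C)[C@@H]2CC(=O)C(C)=C2C1`) gives 632 uM. Compound 3 thus lies within the usual scatter of compound 2, while its number falls below that of compound 1 by more than the scatter.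

Compound 4 (`C=C(C(=O)Nc1ncc(B(O)O)cn1)[C@@H]1CC[C@H](C)[C@@H]2CC(=O)C(C)=C2C1`) keeps the core of compound 3 and differs from it at one place, on an amide-type nitrogen whose other neighbours are: carbonyl carbon. The change is a group of 9 heavy atoms (4 carbon, 1 boron, 2 nitrogen, 2 oxygen; one six-membered aromatic ring with 2 hetero atoms) in place of a group of 9 heavy atoms (6 carbon, 1 boron, 2 oxygen; one six-membered aromatic ring of carbon only), on an amide-type nitrogen. Among the compounds with values here, the aromatic ring with 2 hetero atoms that enters here appears in no measured compound, so the data hold no direct precedent for it.

Within the data shown here, only one measured step bears on this place: a 1.5-fold lower number from compound 2 to compound 3 (0.17 log units; within the scatter). That step stays within the scatter, but it exchanges two groups of identical atom counts, so it offers only indirect guidance. On that limited evidence, no step beyond the scatter is expected in this assay. The estimated step is a 1.2-fold higher number from compound 3 to compound 4 (0.07 log units; within the scatter). For compound 4 the expected value is 750 uM, with an estimated range from 320 uM to 1700 uM.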

Compound 4, half-maximal toxic concentration: 315 uM
Compound 4: middle estimate off by 2.4-fold (0.38 log units), on the high side; measured number below the stated range.
By their numbers in this assay, from the lowest: compounds 4, 3, 2 and 1 (each within the scatter of the next, the first and the last beyond it).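

Within the data shown here, at this place on the amide-type nitrogen, the aromatic ring with 2 hetero atoms gives a 2.0-fold lower number from compound 3 to compound 4 (0.30 log units; within the scatter) in this assay against the one carbon-only group, and a 3.0-fold lower number from compound 2 to compound 4 (0.47 log units; beyond the scatter) against the other. Among these compounds, the second of these is the first step at this place to pass beyond the scatter, so an exchange that keeps the count of 9 heavy atoms and adds ring hetero atoms can still shift tolerance in these cells by a modest amount, although how far depends on which carbon-only group serves as the reference. No supporting measurement is available to explain this shift, so the data record the size of the step and not its origin.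

The compounds shown leave open whether a six-membered aromatic ring with a single ring nitrogen would fall with the carbon-only groups or with the ring of compound 4. Among the compounds shown here, they also leave open how this assay would respond if a carboxylic acid or an amine took the place of the boronic acid on these rings, since every aromatic group at this place so far carries that same boron-containing group.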